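The source may report more compounds than this note shows. Statements on the series, on what has been measured and on what is new or still open speak of the compounds shown alone.

The measured compounds:
Compound 1, `COC(=O)[C@@]1(C)CC[C@@H]2C3=C1CC[C@@H](C)[C@]3(C)C[C@@H]1c3cc(C)ccc3N[C@H]21`: 23000 nM
Compound 2, `COC(=O)[C@@]1(C)CC[C@@H]2C3=C1CC[C@@H](C)[C@]3(C)C[C@@H]1c3cc(Br)ccc3N[C@H]21`: 31000 nM
Compound 3, `COC(=O)[C@@]1(C)CC[C@@H]2C3=C1CC[C@@H](C)[C@]3(C)Cc1c2[nH]c2ccc(C)cc12`: 16000 nM

All three were tested in a functional assay on T47D cells (Homo sapiens) for inhibition, read by sulforhodamine B assay, with a stated time of 48 h; a lower number here means a stronger inhibitor of growth, a higher number a weaker inhibitor of growth. Compound 1 and compound 2 share one core and differ in a single place: bromo in place of methyl on an aromatic carbon. That change gave a 1.3-fold higher number from compound 1 to compound 2 (0.13 log units; within the scatter). Compound 3 is built on a different core; how that core differs from the core of compound 1 is not broken down here. In this assay compound 3 gives 16000 nM, and its gaps to compound 1 and to compound 2 both lie within the usual scatter, so the three values cannot be put in an order.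

Compound 4, `COC(=O)[C@@]1(C)CC[C@@H]2C3=C1CC[C@@H](C)[C@]3(C)Cc1c2[nH]c2ccc(Br)cc12`, has not yet been measured. It is related to compound 3 by the same change that turns compound 1 into compound 2: bromo in place of methyl on an aromatic carbon. The surroundings of the exchanged group are described in the same way for both pairs, so this is the same change, now seen for the second time. Going by the values given here, the only guide to its effect is the one measured instance, which was small and within the scatter. The step from compound 3 to compound 4 is therefore expected to be about a 1.3-fold higher number from compound 3 to compound 4 (0.12 log units; within the scatter), resting on the measured step of a 1.3-fold higher number from compound 1 to compound 2 (0.13 log units; within the scatter). Compound 4 is estimated at 21000 nM in this assay, with an expected range from 10000 nM to 45000 nM, the width reflecting that a single small step is a thin basis.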

Compound 4, concentration for 50% growth inhibition: 21000 nM
Compound 4: middle estimate and measured number agree at the digits printed, and the stated range covers the measured number.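

In this assay, putting bromo in place of methyl on an aromatic carbon of the core of compound 3 gave a 1.3-fold higher number from compound 3 to compound 4 (0.12 log units; within the scatter). Set beside the earlier case, the change looks the same on both cores: the same change on two cores in this assay, a 1.3-fold higher number (0.13 log units; within the scatter) from compound 1 to compound 2 and a 1.3-fold higher number (0.12 log units; within the scatter) from compound 3 to compound 4, 1.0-fold (0.01 log units) apart, within the scatter of two such steps. So in these two pairs the exchange carries over from one core to the other as a step too small to read, but this does not prove that bromo and methyl are equivalent in this series, and two small steps make a weak test of transfer, as neither pair contains a clear effect that could be seen to carry across.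

The compounds shown leave open what other groups on this aromatic carbon would do, such as a hydrogen, a fluoro, a methoxy or an amine, and whether any of them would shift the number beyond the scatter on either core. They also leave open what happens away from this spot, for instance if the methyl ester that all four compounds carry gave way to a carboxylic acid or an amide.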